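Swapping the side chain of compound 2

A few compounds are considered here, and "the series" means these few. Any claim that something is new, unique, unknown or untested is made for them only; others in the source may bear on it.

In a functional assay (on this read-out higher numbers stand for weaker inhibition and lower numbers for stronger inhibition), compound 1 `C=CC(C)(C)c1[nH]c2ccc(C[C@@H](Cl)C(C)(C)O)cc2c1/C=C1\NC(=O)[C@H](C)NC1=O` gives 97000 nM and compound 2 `C=CC(C)(C)c1[nH]c2ccc(C[C@@H](O)C(=C)C)cc2c1/C=C1\NC(=O)[C@H](C)NC1=O` gives 75000 nM. Among the compounds with values here, the one measured step, a 1.3-fold lower number from compound 1 to compound 2 (0.11 log units; within the scatter), lies within the scatter, so compound 2 stands level with compound 1 and the two numbers cannot be told apart.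

Compound 3 `C=CC(C)(C)c1[nH]c2ccc(C[C@H]3OC(C)(C)OC3(C)C)cc2c1/C=C1\NC(=O)[C@H](C)NC1=O` has not been measured yet. It keeps the shared core and changes one group 2,2,5,5-tetramethyl-1,3-dioxolan-4-yl in place of 1-hydroxy-2-methylprop-2-en-1-yl on a saturated chain carbon bound to an aromatic carbon. The entering group is a five-membered non-aromatic ring, while the group that leaves has no ring.

Within the data shown here, only one measured change touches this place, the one that produced compound 2, and its step of a 1.3-fold lower number from compound 1 to compound 2 (0.11 log units; within the scatter) stayed within the scatter. It involved no ring, so it is thin guidance, and no direction can be read from it. In this assay the expected step is therefore none beyond the scatter, a 1.1-fold higher number from compound 2 to compound 3 (0.03 log units; within the scatter). For compound 3 the estimate is 80000 nM, with an expected range of 30000 nM to 200000 nM.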

Compound 3, half-maximal inhibitory concentration: 88000 nM
For compound 3 the middle estimate is 1.1-fold (0.04 log units) below the measured one; low and high end bracket the measured number.
By their numbers in this assay, from the lowest: compounds 2, 3 and 1 (each within the scatter of the next).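

Placing 2,2,5,5-tetramethyl-1,3-dioxolan-4-yl on the saturated chain carbon bound to an aromatic carbon, in place of 1-hydroxy-2-methylprop-2-en-1-yl, gives a 1.2-fold higher number from compound 2 to compound 3 (0.07 log units; within the scatter) in this assay. Within the data shown here, this is the first ring at this place, and the swap also takes the count from 5 to 9 heavy atoms and from 1 hydrogen-bond donor to 0, yet the number stays within the scatter. Measured against the chlorine-bearing side chain, the same ring gives a 1.1-fold lower number from compound 1 to compound 3 (0.04 log units; within the scatter), so all three side chains now read as level, and nothing available explains why these different groups cannot be told apart.

With every step inside the scatter, these three compounds do not reveal whether any feature of the side chain at this place affects the read-out. On these data alone, whether a group of another kind, such as an amine or a carboxylic acid, would move the number beyond the scatter remains open, and so does the effect of the ring's opposite stereochemistry.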